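A few compounds are considered here, and "the series" means these few. Any claim that something is new, unique, unknown or untested is made for them only; others in the source may bear on it.

Compound 1 `Cc1ccc2nc(N3CCCc4ccc(F)cc4C3)cc(NCC3(N)COC3)c2c1`: in an ADME assay on HEp-2 cells (Homo sapiens) for cytotoxicity, read by CCK-8 assay, with a stated time of 5 days (a lower number here means that less compound is tolerated, a higher number that more compound is tolerated), compound 1 gives > 100000 nM, which is a limit of the assay and not a number.
Compound 2 `CNCCNc1cc(N2CCCc3ccc(F)cc3C2)nc2ccc(C)cc12`: in this assay compound 2 gives 29000 nM.

Compound 2 holds the only plain number shown in this assay. For the measured compounds named here, the value of compound 1 is a limit (the limit of > 100000 nM in this assay, at which 1 of the 2 values shown sits), so only one side of that comparison is fixed.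

Compound 3 `Cc1ccc2nc(N3CCCc4ccc(F)cc4C3)cc(NCCN(C)C)c2c1` differs from compound 2 by methyl in place of hydrogen on an amine nitrogen. A single measured step exists, an at least 3.4-fold lower number from compound 1 to compound 2 (0.53 log units; beyond the scatter); it exchanges a different, larger group and does not itself test a methyl on an amine nitrogen, so it bears on the present change only loosely. It shows that alterations on this chain can shift the number beyond the scatter, but its direction need not carry over. For a change of one carbon the expected shift is a 1.5-fold lower number from compound 2 to compound 3 (0.16 log units; within the scatter), within or close to the scatter. Compound 3 is therefore estimated at 20000 nM, with a range from 7000 nM to 60000 nM.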

Compound 3, half-maximal cytotoxic concentration: 89000 nM
The estimate for compound 3 lay 4.5-fold (0.65 log units) below the measured number; the measured number lies above the stated range.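

In this assay, methyl in place of hydrogen on an amine nitrogen gives a 3.1-fold higher number from compound 2 to compound 3 (0.49 log units; beyond the scatter). For the compounds shown here, this shift toward more compound being tolerated is the first direct test of this change, whereas the earlier measured step exchanged a larger group. The value of compound 1 is a limit: the limit of > 100000 nM in this assay, at which 1 of the 3 values shown sits. The step across that limit is an at least 1.1-fold lower number from compound 1 to compound 3 (0.05 log units; that floor lies within the scatter), and it fixes no order between the two.

Going by these compounds, whether the number keeps moving the same way with an ethyl group on this nitrogen, with the nitrogen built into a pyrrolidine ring, or with a longer chain remains open. This methyl change rests on a single pair of compounds, so whether it has the same effect on a different core is also unknown.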